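The source may report more compounds than this note shows. Statements on the series, on what has been measured and on what is new or still open speak of the compounds shown alone.

In a functional assay on A549 cells (Homo sapiens) for cytotoxicity, read by MTT assay, with a stated time of 48 h (a lower number here means a stronger inhibitor, a higher number a weaker inhibitor), compound 1 `CCOC(=O)[C@]1(C(=O)Nc2ccccc2)C[C@H]1c1cc(OC)c(OC)c(OC)c1` gives 37300 nM and compound 2 `CCOC(=O)[C@]1(C(=O)Nc2ccccc2)C[C@@H]1c1cc(OC)c(OC)c(OC)c1` gives 21300 nM. These two values lie within the scatter of each other, so neither compound can be ranked above the other. For the measured compounds named here, the only measured step is a 1.8-fold lower number from compound 1 to compound 2 (0.24 log units; within the scatter), and it concerns (the fact that compounds 1 and 2 differ only in the configuration as drawn).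

Compound 3 `CCOC(=O)[C@]1(C(=O)Nc2ccccc2Cl)C[C@@H]1c1cc(OC)c(OC)c(OC)c1` keeps the configuration of compound 2 and makes one structural change: chloro in place of hydrogen on an aromatic carbon. The chloro takes the place of hydrogen on an aromatic carbon of a six-membered aromatic ring of carbon only, ortho to a large group. Going by the values given here, no measured step touches that ring, so the single step available gives no direct measure of what this change will do. The expectation therefore stays close to compound 2 at 21300 nM, with no step beyond the scatter and no firm direction in this assay.

The estimate implies a 1.2-fold lower number from compound 2 to compound 3 (0.07 log units; within the scatter), which is expected to remain within the scatter. For compound 3 the expected value is 18000 nM, with an estimated range from 7000 nM to 45000 nM.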

Compound 3, half-maximal inhibitory concentration: 50900 nM
Compound 3: the middle estimate sits 2.8-fold (0.45 log units) below what was measured; measured number above the stated range.
By their numbers in this assay, from the lowest: compounds 2, 1 and 3 (each within the scatter of the next, the first and the last beyond it).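

In this assay, placing chloro on an aromatic carbon of the anilide's six-membered ring, ortho to a large group, gives a 2.4-fold higher number from compound 2 to compound 3 (0.38 log units; beyond the scatter) and so makes compound 3 a modestly weaker inhibitor than compound 2. For the compounds shown here, this is the first measure of any change on this ring, and it shows that the position is not indifferent to substitution: swapping a single hydrogen for chloro moves the number beyond the scatter, whereas the only earlier step, between compound 1 and compound 2, stayed within it. What is known about these compounds says nothing about why chloro has this effect in these cells.

A single substituent at a single position cannot show whether the loss belongs to chloro itself or would also follow with fluoro, methyl, methoxy or an amine in the same place, or with chloro on another carbon of this ring. It also remains open whether the same change would carry over to the configuration of compound 1, since the chloro group is shown only in the configuration of compound 2.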